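The source may hold more compounds than are shown below. What is called first, only, known or untested is meant among the compounds shown, and "the series" means these compounds.

Compound 1 `Nc1nc(N)c2c(-c3ccoc3)cn([C@@H]3O[C@H](CO)[C@@H](O)[C@H]3O)c2n1` is the reference point of the series. In a functional assay on K562 cells (Homo sapiens), read by MTT assay, with a stated time of 72 h (a higher number here means a weaker inhibitor, a lower number a stronger inhibitor), compound 1 returns only a limit, > 20000 nM. Compound 2 `Nc1nc(N)c2c(-c3ccccc3)cn([C@@H]3O[C@H](CO)[C@@H](O)[C@H]3O)c2n1` carries phenyl in place of furan-3-yl on an aromatic carbon; in this assay compound 2 likewise returns a limit, > 20000 nM. Compound 3 `Nc1nc(N)c2c(-c3ccco3)cn([C@@H]3O[C@H](CO)[C@@H](O)[C@H]3O)c2n1` carries furan-2-yl in place of furan-3-yl on an aromatic carbon; in this assay compound 3 again returns a limit, > 20000 nM. The three measured steps, a step that the two limits leave unreadable from compound 1 to compound 2, a step that the two limits leave unreadable from compound 1 to compound 3 and a step that the two limits leave unreadable from compound 2 to compound 3, therefore carry no readable size, since the limit of > 20000 nM in this assay, at which 3 of the 3 values shown sit, holds for every value shown.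

Compound 4 `Cc1nc(N)c2c(-c3ccoc3)cn([C@@H]3O[C@H](CO)[C@@H](O)[C@H]3O)c2n1` differs from compound 1 by methyl in place of amino on an aromatic carbon. No measured step touches this change; the steps that exist concern the furan-3-yl, phenyl and furan-2-yl groups and are themselves unreadable, so nothing shown bears on the size or the direction of what follows. Within the data shown here, the only guide is that compound 1 gives > 20000 nM, a limit. Compound 4 is therefore expected to return a comparable limit, with an estimated step that the limit leaves unreadable from compound 1 to compound 4. The estimate for compound 4 is 30000 nM, ranging from 8000 nM to 100000 nM.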

Compound 4, half-maximal inhibitory concentration: > 20000 nM
Compound 4 gave a limit, no number; the forecaster's own chance of this, stated with the estimate: 75%; the middle value is on the limit's open side.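

No new step can be read between compound 1 and compound 4, as both return only a limit: the limit of > 20000 nM in this assay, at which 4 of the 4 values shown sit.

The compounds shown leave open whether amino, methyl, furan-3-yl, phenyl or furan-2-yl makes any difference on the shared core in this assay, as none of them yields a number.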